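A few compounds are considered here, and "the series" means these few. Any claim that something is new, unique, unknown or untested is made for them only; others in the source may bear on it.

Compound 2 `COc1cc2nc(N3CCN(/C(S)=N/C4CCCCC4)CC3)nc(N)c2cc1OC` gives 5.37 nM in an assay for binding affinity to Adrenergic receptor alpha-1 (Rattus norvegicus) (on this read-out higher numbers stand for weaker inhibition and lower numbers for stronger inhibition), the higher of the two numbers seen; compound 1 `COc1cc2nc(N3CCN(/C(S)=N/c4ccccc4)CC3)nc(N)c2cc1OC` gives 0.00692 nM. Compound 3 `COc1cc2nc(N3CCN(S(=O)(=O)c4cccs4)CC3)nc(N)c2cc1OC` differs from compound 2 in that (a group of 8 heavy atoms (4 carbon, 2 oxygen, 2 sulfur; one five-membered aromatic ring with 1 hetero atom) in place of a group of 9 heavy atoms (7 carbon, 1 nitrogen, 1 sulfur; one six-membered non-aromatic ring of carbon only), on an amine nitrogen in a ring). Going by the values given here, no measured step matches this change; the only step available, a 780-fold higher number from compound 1 to compound 2 (2.89 log units; beyond the scatter), shows that what sits on this ring nitrogen can shift the number a great deal, and compound 3 brings an aromatic ring back into that place. A step of a 5.4-fold lower number from compound 2 to compound 3 (0.73 log units; beyond the scatter) toward a lower number is therefore expected, so compound 3 is estimated at 1 nM, within 0.1 nM to 20 nM.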

Compound 3, half-maximal inhibitory concentration: 33.9 nM
Beside the measured number, compound 3's estimate is 34-fold (1.53 log units) below it, and the stated range ends below it.
By their numbers in this assay, from the lowest: compound 1; then compound 2; then compound 3.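

In this assay, the (thiophen-2-yl)sulfonyl group on the ring nitrogen gives a 6.3-fold higher number from compound 2 to compound 3 (0.80 log units; beyond the scatter) and a 4900-fold higher number from compound 1 to compound 3 (3.69 log units; beyond the scatter) in this comparison. An aromatic ring in this place therefore does not by itself bring back the very low number of compound 1, so the rest of the group must count too. Nothing available here explains these steps. A phenylsulfonyl group would keep the sulfonyl link of compound 3 with the ring of compound 1, leaving open whether the link or the ring matters more.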